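Nitro for Bromo on Two Related Cores in A549 Cells

The source may hold more compounds than are shown below. What is called first, only, known or untested is meant among the compounds shown, and "the series" means these compounds.

Measured so far:
compound 1 `Brc1ccc(C(c2c[nH]c3ccc(Br)cc23)c2c[nH]c3ccc(Br)cc23)cc1` — 5600 nM
compound 2 `O=[N+]([O-])c1ccc(C(c2c[nH]c3ccc(Br)cc23)c2c[nH]c3ccc(Br)cc23)cc1` — 5500 nM
compound 3 `OC[C@H]1O[C@@H](n2cc(C(c3ccc(Br)cc3)c3cn([C@@H]4O[C@H](CO)[C@@H](O)[C@H](O)[C@H]4O)c4ccc(Br)cc34)c3cc(Br)ccc32)[C@H](O)[C@@H](O)[C@@H]1O` — 2500 nM

Compounds 1 and 2 share one core; compound 3 has another, and the difference between the two cores is not broken down here. All three were tested in a functional assay on A549 cells (Homo sapiens) for inhibition, read by MTT assay, with a stated time of 48 h; a lower number here means a stronger inhibitor, a higher number a weaker inhibitor. In this assay compound 1 gives 5600 nM and compound 2 gives 5500 nM; the two lie within the scatter of each other. Compound 3 gives 2500 nM, the lowest of the three and beyond the scatter from both, so among these it is the strongest inhibitor.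

The change from compound 1 to compound 2 is nitro in place of bromo on an aromatic carbon, and its step was a 1.0-fold lower number from compound 1 to compound 2 (0.01 log units; within the scatter).

Compound 4 `O=[N+]([O-])c1ccc(C(c2cn([C@@H]3O[C@H](CO)[C@@H](O)[C@H](O)[C@H]3O)c3ccc(Br)cc23)c2cn([C@@H]3O[C@H](CO)[C@@H](O)[C@H](O)[C@H]3O)c3ccc(Br)cc23)cc1` has not been measured. It differs from compound 3 by nitro in place of bromo on an aromatic carbon, the same change, at the same kind of place. Because a 1.0-fold lower number from compound 1 to compound 2 (0.01 log units; within the scatter) was essentially flat, the expected step on the core of compound 3 is no change at the digits printed from compound 3 to compound 4 (within the scatter), a near-unchanged number. The estimate for compound 4 is 2500 nM, expected to fall between 1200 nM and 5200 nM.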

Compound 4, half-maximal inhibitory concentration: 2400 nM
The estimate for compound 4 lay 1.0-fold (0.02 log units) above the measured number, and the stated range covers the measured number.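

In this assay, putting nitro in place of bromo on the core of the sugar-bearing compounds gave a 1.0-fold lower number from compound 3 to compound 4 (0.02 log units; within the scatter), so this swap leaves the number as flat here as it did on the first core. The two steps agree, which means that in this small set the result of the swap carried over from one core to the other: the same change on two cores in this assay, a 1.0-fold lower number (0.01 log units; within the scatter) from compound 1 to compound 2 and a 1.0-fold lower number (0.02 log units; within the scatter) from compound 3 to compound 4, 1.0-fold (0.01 log units) apart, within the scatter of two such steps

Going by these compounds alone, this is only one change compared on two cores, so it does not show that the swap would stay flat on any further core, it does not explain why the number holds steady, and a reading from this one cell assay says nothing about how the compounds would behave in any other test.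

The compounds shown carry only bromo or nitro on that aromatic carbon, so it remains open whether an amine, a carboxylic acid or a longer chain there would also leave the number in place. They also leave open which part of the difference between the two cores accounts for the lower number of compound 3.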